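Replacing the Vinyl Group of Compound 2

A few compounds are considered here, and "the series" means these few. Any claim that something is new, unique, unknown or untested is made for them only; others in the source may bear on it.

Compound 1 `C=CCCCCC/C=C\[C@H](O)C#CC#CC1OC1C` gives 70600 nM
Compound 2 `C=CC(O)C#CC#C[C@@H](O)[C@H](C)O` gives 177000 nM

In an ADME assay on Hepa-1c1c7 cells (Mus musculus) for cytotoxicity (a higher number here means a weaker inhibitor, a lower number a stronger inhibitor), compound 2 stands highest of the two measured compounds (177000 nM) and compound 1 lies lower (70600 nM). The gap between the two lies beyond the scatter. Compound 3 `CC(C)=CC(O)C#CC#C[C@@H](O)[C@H](C)O`, not yet measured, carries 2-methylprop-1-en-1-yl in place of vinyl on a saturated chain carbon bound to an oxygen on a saturated carbon and a triple-bonded carbon. Among the measured compounds shown here, no measured pair isolates this change, and compound 1 and compound 2 differ in more than one place. For the measured compounds named here, the only guide is the lower number of compound 1 (70600 nM), so a small downward step in this assay is expected, probably none beyond the scatter. The expected step is small (a 1.4-fold lower number from compound 2 to compound 3 (0.15 log units; within the scatter)). Compound 3 is estimated at 125000 nM (expected range 55000 nM to 260000 nM).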

Compound 3, half-maximal inhibitory concentration: 406000 nM
For compound 3 the middle estimate is 3.2-fold (0.51 log units) below the measured one; the measured number lies above the stated range.
By their numbers in this assay, from the lowest: compound 1; then compound 2; then compound 3.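

Among the compounds shown here, putting 2-methylprop-1-en-1-yl in place of vinyl on this saturated chain carbon gives the first one-place comparison in this assay, and the change shows a 2.3-fold higher number from compound 2 to compound 3 (0.36 log units; beyond the scatter). The position is therefore not indifferent to what it carries: a double bond outside aromatic rings stands in both groups, yet the larger group gives the weaker inhibitor of this pair. Nothing measured here explains the shift.

A single pair cannot tell whether the branched end of the new group or its overall size goes with the higher number. Also open, as far as these compounds go, is how a saturated isobutyl group, a phenyl ring or a longer unbranched alkenyl chain at this position would read, and whether the step would hold on a different core.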